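The source may hold more compounds than are shown below. What is called first, only, known or untested is meant among the compounds shown, and "the series" means these compounds.

Measured so far:
Compound 1 `Cc1c(F)c(Oc2cccc(N)c2)nc(Oc2cccc(C(=N)N)c2)c1F` — in an assay on isolated protein for inhibition of serine protease 1 (Bos taurus) (on this read-out higher numbers stand for weaker inhibition and lower numbers for stronger inhibition), compound 1 gives > 5000 nM, which is a limit of the assay and not a number.
Compound 2 `Cc1c(F)c(Oc2cccc(CC(N)=O)c2)nc(Oc2cccc(C(=N)N)c2)c1F` — in this assay compound 2 gives > 5000 nM, again a limit of the assay rather than a number.

Both values sit at the limit of > 5000 nM in this assay, at which 2 of the 2 values shown sit, so the step that the two limits leave unreadable from compound 1 to compound 2 cannot be read, and compound 2 stands at that limit with nothing more precise known about it.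

Compound 3 `Cc1c(Oc2nc(Oc3cccc(C(=N)N)c3)c(F)c(C)c2F)cccc1N(C)C` differs from compound 2 by 3-(dimethylamino)-2-methylphenyl in place of 3-(carbamoylmethyl)phenyl on an oxygen on an aromatic ring. Among the measured compounds shown here, no measured step bears on this change: the only step available, that from compound 1 to compound 2, is unreadable, and neither measured compound has a numerical value. The expectation for compound 3 therefore rests on both known compounds sitting at the limit, and compound 3 is expected to stay there as well, with no readable step that the limit leaves unreadable from compound 2 to compound 3. Compound 3 is estimated at 8000 nM, within a range from 3000 nM to 30000 nM.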

Compound 3, inhibition constant: 5000 nM
Compound 3: the middle estimate sits 1.6-fold (0.20 log units) above what was measured; the measured number falls inside the stated range.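

In this assay, among the compounds shown here, compound 3 gives 5000 nM, the first value in this set that is a number and not a limit of the assay. With 3-(dimethylamino)-2-methylphenyl on an oxygen on an aromatic ring, the shared core therefore gives a readable value, which 3-aminophenyl and 3-(carbamoylmethyl)phenyl in that place did not. The data give a number no higher from compound 2 to compound 3 (the limit leaves the size open) and a number no higher from compound 1 to compound 3 (the limit leaves the size open) but the size of neither step can be read, because the other value in each pair is a limit: the limit of > 5000 nM in this assay, at which 2 of the 3 values shown sit.

The compounds shown leave open whether the dimethylamino group or the methyl group carries this difference, as the two enter together. They also leave open how a carboxylic acid, a piperidine or a longer chain on this phenyl would read in this assay.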